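From Phenyl to 3,4-Dimethylphenyl on Compound 1

This account rests on a few compounds, and the source may have more. Where it says the series, first, only, none or still open, it means among the compounds named here.

Measured compounds:
compound 1, `CC1CCC(=NNc2ccccc2)c2ncc(C(=O)O)c(=O)n21`, 1.2 umol/kg
compound 2, `CC1CCC(=NNc2ccccc2C(=O)O)c2ncc(C(=O)O)c(=O)n21`, > 100 umol/kg, which is a limit of the assay and not a number

In a functional assay on the whole organism with Rattus norvegicus as the target (a higher number here means that more compound is needed for the effect, a lower number that less compound is needed), compound 1 holds the only number shown. For compound 2 the result is a limit of the assay, described by the limit of > 100 umol/kg in this assay, at which 1 of the 2 values shown sits. For the measured compounds named here, the single measured step, an at least 83-fold higher number from compound 1 to compound 2 (1.92 log units; beyond the scatter), comes from placing carboxy in place of hydrogen on an aromatic carbon, so the number rose sharply when an acid group was added to the aryl ring.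

Compound 3, `Cc1ccc(NN=C2CCC(C)n3c2ncc(C(=O)O)c3=O)cc1C`, has not yet been measured. It differs from compound 1 as follows: 3,4-dimethylphenyl in place of phenyl on an amine nitrogen. Going by the values given here, the change is a different one from the measured step: no acid is added, only two methyl groups on the same ring, so the large step from compound 1 to compound 2 does not bear directly on it. Among the compounds with values here, with no step of this kind measured, the expectation is a step within the usual scatter, a 1.3-fold higher number from compound 1 to compound 3 (0.10 log units; within the scatter), in no clear direction. Compound 3 is therefore estimated at 1.5 umol/kg, with a range from 0.4 umol/kg to 6 umol/kg.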

Compound 3, dose for 50% inhibition: > 100 umol/kg
Compound 3 gave a limit, no number; the forecaster's own chance of this, stated with the estimate: 10%; middle value at least 66-fold (1.82 log units) away from the limit.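

In this assay, the step of an at least 83-fold higher number from compound 1 to compound 3 (1.92 log units; beyond the scatter) shows that this position can lose the effect without any acid being added, since 3,4-dimethylphenyl in place of phenyl on the amine nitrogen adds only carbon. Compound 2 alone could not show this, as it left open whether the large step belonged to the carboxy group in particular, whereas the two methyl groups of compound 3 now show that a change with no carboxy group also gives a large step. For compound 3, > 100 umol/kg is a limit of the assay and not a number, so the full size of the step stays unknown, and compound 2 and compound 3 cannot be ranked against each other: the limit of > 100 umol/kg in this assay, at which 2 of the 3 values shown sit.

The compounds shown leave open whether a single methyl group on the phenyl ring would already give so large a step, or whether the number would stay close to that of compound 1, 1.2 umol/kg. They also leave open how a fluorine atom, a methoxy group or an amine on that ring would behave.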